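Replacing a benzylamine link with a phenyl ether

A few compounds are considered here, and "the series" means these few. Any claim that something is new, unique, unknown or untested is made for them only; others in the source may bear on it.

Going by the values given here, compound 2 `Nc1cc(N)c2nc(-c3ccccc3)c(NCc3ccc(F)cc3)nc2c1` gives 25700 nM in a functional assay on NCI-H460 cells (Homo sapiens) for inhibition, read by sulforhodamine B assay, with a stated time of 48 h (a lower number here means a stronger inhibitor of growth, a higher number a weaker inhibitor of growth), the lower of the two numbers known, while compound 1 `COc1ccc(CNc2nc3cc(N)cc(N)c3nc2-c2ccccc2)cc1OC` gives 91200 nM; the step of a 3.5-fold lower number from compound 1 to compound 2 (0.55 log units; beyond the scatter) separates them. Compound 3 `Nc1cc(N)c2nc(-c3ccccc3)c(Oc3ccc(F)cc3)nc2c1` carries the change (4-fluorophenoxy in place of (4-fluorobenzyl)amino on an aromatic carbon). Among the compounds with values here, the only measured step concerns the substituent pattern of the benzyl group and not the link to the core, so it offers no direct guide; a modest step in either direction, or none beyond the scatter, is plausible. Compound 3 is therefore expected to give about 35000 nM in this assay, ranging from 10000 nM to 120000 nM, a step of a 1.4-fold higher number from compound 2 to compound 3 (0.13 log units; within the scatter) that is estimated rather than measured.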

Compound 3, concentration for total growth inhibition: < 100000 nM
Compound 3: no number, only a limit (the forecaster's own chance of this, stated with the estimate: 5%); the middle value does not contradict the limit.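

In this assay, going by these compounds alone, compound 3 gives only a limit, < 100000 nM, so no step from compound 2 to compound 3 can be read. Going by these compounds, whether 4-fluorophenoxy in place of (4-fluorobenzyl)amino lowers or raises the number remains open.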